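Ring expansion of the amide amine in bradykinin antagonists

The source may hold more compounds than are shown below. What is called first, only, known or untested is meant among the compounds shown, and "the series" means these compounds.

Compound 1 `Cc1cc(S(=O)(=O)N2C=CNC(=O)[C@H]2CC(=O)N[C@H]2CCNCC2(C)C)c(C)cc1Cl`: 0.31 nM
Compound 2 `Cc1cc(S(=O)(=O)N2C=CNC(=O)[C@H]2CC(=O)N2CCC(N(C)C)CC2)c(C)cc1Cl`: 152 nM
Compound 3 `Cc1cc(S(=O)(=O)N2C=CNC(=O)[C@H]2CC(=O)N2CCC[C@H](N3CCCC3)C2)c(C)cc1Cl`: 38 nM

In an in vitro functional assay on cells for antagonist activity at B1 bradykinin receptor (Homo sapiens), read by luminescence and calcium flux, with a stated time of 2 h (a higher number here means a weaker inhibitor, a lower number a stronger inhibitor), compound 3 stands second highest of the three numbers, giving 38 nM; the nearest is compound 2, with a 4.0-fold lower number from compound 2 to compound 3 (0.60 log units; beyond the scatter), and the furthest is compound 1, with a 120-fold higher number from compound 1 to compound 3 (2.09 log units; beyond the scatter). Compound 4 `Cc1cc(S(=O)(=O)N2C=CNC(=O)[C@H]2CC(=O)N2CCCCC(N(C)C)CC2)c(C)cc1Cl` differs from compound 3 by a group of 11 heavy atoms (9 carbon, 2 nitrogen; one eight-membered non-aromatic ring with 1 hetero atom) in place of a group of 11 heavy atoms (9 carbon, 2 nitrogen; one five-membered non-aromatic ring with 1 hetero atom, one six-membered non-aromatic ring with 1 hetero atom), on a carbonyl carbon. Among the compounds with values here, the steps that bear on this are the exchange of one cyclic amine on the same carbonyl for another: a 490-fold higher number from compound 1 to compound 2 (2.69 log units; beyond the scatter) and a 4.0-fold lower number from compound 2 to compound 3 (0.60 log units; beyond the scatter), both beyond the scatter. Compound 4 carries the same dimethylamino substitution as compound 2, so a modest rise toward that number is expected, a 3.9-fold higher number from compound 3 to compound 4 (0.60 log units; beyond the scatter). Compound 4 is therefore estimated at 150 nM, within 30 nM to 800 nM.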

Compound 4, half-maximal inhibitory concentration: 4.75 nM
Compound 4: the middle estimate sits 32-fold (1.50 log units) above what was measured; measured number outside the range, below it.
By their numbers in this assay, from the lowest: compound 1; then compound 4; then compound 3; then compound 2.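

Keeping the dimethylamino substitution of compound 2 while enlarging the ring to the eight-membered one gave a 32-fold lower number from compound 2 to compound 4 (1.51 log units; beyond the scatter) on the same carbonyl carbon, so the ring carrying that amine matters strongly at this position. The eight-membered ring also outperformed the two-ring group of compound 3, with an 8.0-fold lower number from compound 3 to compound 4 (0.90 log units; beyond the scatter) in the same direction. It still fell short of the group in compound 1, with a 15-fold higher number from compound 1 to compound 4 (1.19 log units; beyond the scatter) remaining.

No measurement shown here explains these differences. As far as these compounds go, whether a seven-membered ring, or a pyrrolidine or primary amine on the eight-membered ring, would narrow that remaining distance stays open.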